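Removing the isopropyl side chain: compound 2 to compound 3

A few compounds are considered here, and "the series" means these few. Any claim that something is new, unique, unknown or untested is made for them only; others in the source may bear on it.

The series shares one core. Compound 1 `Cc1ncc([N+](=O)[O-])n1CCOC(=O)c1cc(NC(=O)[C@H](CCCCN)NC(=O)OCc2ccccc2)ccc1O` carries 4-aminobutyl on a saturated chain carbon bound to an amide-type nitrogen and a carbonyl carbon; compound 2 `Cc1ncc([N+](=O)[O-])n1CCOC(=O)c1cc(NC(=O)[C@@H](NC(=O)OCc2ccccc2)C(C)C)ccc1O` carries isopropyl at that place. In a functional assay on the whole organism (strain Wistar) for inhibition, with Rattus norvegicus as the target, read by paw edema, with stated times of 1 h and 4 h, at a dose of 10 mg/kg by the intraperitoneal route (on this read-out lower numbers stand for less inhibition and higher numbers for more inhibition at the one dose given (going by the name of the read-out)), compound 1 gives 33.5% and compound 2 gives 58.2%. Compound 2 stands highest of the two numbers; the nearest is compound 1, and the step of a number 24.7 percentage points higher from compound 1 to compound 2 (beyond the scatter) lies beyond the scatter. Compound 3 `Cc1ncc([N+](=O)[O-])n1CCOC(=O)c1cc(NC(=O)CNC(=O)OCc2ccccc2)ccc1O` differs from compound 2 by hydrogen in place of isopropyl on a saturated chain carbon bound to an amide-type nitrogen and a carbonyl carbon. Going by the values given here, the only measured step touching this place is a number 24.7 percentage points higher from compound 1 to compound 2 (beyond the scatter), a modest rise, but it swaps one group for another rather than removing the group altogether, so its bearing on the present change is indirect. With just this to go on, a step in this assay of moderate size in either direction cannot be ruled out, and the expectation is placed somewhat below compound 2. Compound 3 is expected to give 45%, within 25% to 65%. The expected step is a number 13.2 percentage points lower from compound 2 to compound 3 (beyond the scatter).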

Compound 3, a percentage reported as inhibition, in the whole organism at one dose (the size of the read-out at that dose, not a potency): 52.8%
The estimate for compound 3 lay 7.8 percentage points below the measured number; the range from low to high includes it.
By their numbers in this assay, from the lowest: compound 1; then compounds 3 and 2 (each within the scatter of the next).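

In this assay, taking the isopropyl group away altogether gives a number 5.4 percentage points lower from compound 2 to compound 3 (within the scatter), so on a saturated chain carbon bound to an amide-type nitrogen and a carbonyl carbon, isopropyl and hydrogen cannot be told apart on this read-out, and no group of that kind is needed at this place to reach the number of compound 2. Hydrogen in place of 4-aminobutyl gives a number 19.3 percentage points higher from compound 1 to compound 3 (beyond the scatter), and with a number 24.7 percentage points higher from compound 1 to compound 2 (beyond the scatter) this sets compound 1 apart from both of the others, which shows that the earlier rise was not specific to isopropyl but holds equally for the compound with no side chain at all. Nothing on hand accounts for the separate standing of compound 1.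

From the compounds shown here alone, it stays open whether the number of compound 1 goes with the amine of 4-aminobutyl or with the length of its chain, a question that a plain butyl chain at the same place would address. Going by these compounds, how a chain ending in a carboxylic acid or a side chain bearing a phenyl ring would read at this place also remains open.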